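The source may report more compounds than this note shows. Statements on the series, on what has been measured and on what is new or still open speak of the compounds shown alone.

Compound 3 `CCN(C/C=C/C#CC(C)(C)C)Cc1cccc(OC[Si](C)(C)c2ccccc2C(F)(F)F)c1` sits second highest of the three numbers in a functional assay on liver (Sus scrofa) for inhibition of squalene monooxygenase (Homo sapiens), using microsomes (a higher number here means a weaker inhibitor, a lower number a stronger inhibitor), where compound 3 gives 70 nM. Its closest neighbour is compound 2 `CCN(C/C=C/C#CC(C)(C)C)Cc1cccc(OC[Si](C)(C)c2ccccc2C)c1`, which in this assay gives 30 nM; the step of a 2.3-fold higher number from compound 2 to compound 3 (0.37 log units; beyond the scatter) is modest. Far above both stands compound 1 `CCN(C/C=C/C#CC(C)(C)C)Cc1cccc(OC[Si](C)(C)c2cccc(C)c2)c1`, which gives 3000 nM, and the steps of a 100-fold lower number from compound 1 to compound 2 (2.00 log units; beyond the scatter) and a 43-fold lower number from compound 1 to compound 3 (1.63 log units; beyond the scatter) are the large ones in this set.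

Compound 4 `CCN(C/C=C/C#CC(C)(C)C)Cc1cccc(OC[Si](C)(C)c2ccc(S)cc2)c1` differs from compound 3 in that (4-sulfanylphenyl in place of 2-(trifluoromethyl)phenyl on a silicon). Within the data shown here, no measured step pairs a 4-sulfanylphenyl with any other group, so this change lacks a direct precedent. What the data do show is that the group on the silicon matters greatly: moving from a 3-methylphenyl to a 2-substituted phenyl lowered the number by a large margin in both measured steps, and the identity of that substituent mattered only modestly. A 4-sulfanylphenyl is neither pattern, so compound 4 is expected to land weaker than compound 3, with a wide range, by an 11-fold higher number from compound 3 to compound 4 (1.06 log units; beyond the scatter). Compound 4 is therefore estimated at 800 nM, between 120 nM and 6000 nM.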

Compound 4, half-maximal inhibitory concentration: 8000 nM
The estimate for compound 4 lay 10-fold (1.00 log units) below the measured number; the measured number lies above the stated range.
By their numbers in this assay, from the lowest: compound 2; then compound 3; then compound 1; then compound 4.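

In this assay, 4-sulfanylphenyl on the silicon proves far worse than either earlier group that gave a low number: in place of 2-(trifluoromethyl)phenyl it brings a 110-fold higher number from compound 3 to compound 4 (2.06 log units; beyond the scatter), and in place of 2-methylphenyl it brings a 270-fold higher number from compound 2 to compound 4 (2.43 log units; beyond the scatter). Even against 3-methylphenyl, the poorest group until now, it brings a 2.7-fold higher number from compound 1 to compound 4 (0.43 log units; beyond the scatter), which makes compound 4 the weakest inhibitor of the set and shows that this silicon-bound aryl group can cost still more than the earlier steps revealed. Nothing measured here accounts for this loss.

The compounds shown leave open whether the loss follows the sulfanyl group itself or its place on the ring, as neither 2-sulfanylphenyl nor 4-methylphenyl is among them. From the compounds shown here alone, how an unsubstituted phenyl or a 2-chlorophenyl would fare on the silicon also remains open.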